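Methyl and morpholine effects on a chromone dithiocarbamate series

The source may report more compounds than this note shows. Statements on the series, on what has been measured and on what is new or still open speak of the compounds shown alone.

Measured compounds:
compound 1, `O=c1c(CSC(=S)N2CCCC2)coc2ccccc12`: 2300 nM
compound 2, `Cc1ccc2c(=O)c(CSC(=S)N3CCCC3)coc2c1`: 5900 nM
compound 3, `O=c1c(CSC(=S)N2CCOCC2)coc2ccccc12`: 5900 nM

Three compounds sharing the core of compound 1 were tested in a functional assay on SW480 cells (Homo sapiens) for antiproliferative activity, read by MTT assay, with a stated time of 72 h; a higher number here means a weaker inhibitor, a lower number a stronger inhibitor. Compound 1 gives 2300 nM in this assay and is the lowest number of the three. Compound 2 differs from it by methyl in place of hydrogen on an aromatic carbon, and this change brings a 2.6-fold higher number from compound 1 to compound 2 (0.41 log units; beyond the scatter). Compound 3 differs from compound 1 by morpholin-4-yl in place of pyrrolidin-1-yl on a thiocarbonyl carbon, and that change brings a 2.6-fold higher number from compound 1 to compound 3 (0.41 log units; beyond the scatter). Compound 2 and compound 3 thus stand level with each other at the digits reported, both within the usual scatter of one another.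

Compound 4, `Cc1ccc2c(=O)c(CSC(=S)N3CCOCC3)coc2c1`, has not yet been measured. It differs from compound 3 by methyl in place of hydrogen on an aromatic carbon, which is the same change that carries compound 1 to compound 2; the place of the change is described in the same words for both pairs. Nothing beyond these three compounds is known about how the two changes behave when combined. Going by the values given here, the only guide is the earlier step, and it was modest but beyond the scatter. Because a 2.6-fold higher number from compound 1 to compound 2 (0.41 log units; beyond the scatter), compound 4 is expected to show a similar step, a 2.5-fold higher number from compound 3 to compound 4 (0.41 log units; beyond the scatter), in this assay. Compound 4 is therefore estimated at 15000 nM, with the interval from 6500 nM to 35000 nM covering most repeated measurements. This expectation rests on a single prior step and should be read as provisional.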

Compound 4, half-maximal inhibitory concentration: 3800 nM
For compound 4 the middle estimate is 3.9-fold (0.60 log units) above the measured one; the whole stated range lies above it.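

In this assay, methyl in place of hydrogen on an aromatic carbon gives a 1.6-fold lower number from compound 3 to compound 4 (0.19 log units; within the scatter) once the morpholin-4-yl group is present, and morpholin-4-yl in place of pyrrolidin-1-yl on a thiocarbonyl carbon gives a 1.6-fold lower number from compound 2 to compound 4 (0.19 log units; within the scatter) once the methyl group is present. The methyl step therefore does not carry over from one core to the other in this series: the same change on two cores in this assay, a 2.6-fold higher number (0.41 log units; beyond the scatter) from compound 1 to compound 2 and a 1.6-fold lower number (0.19 log units; within the scatter) from compound 3 to compound 4, 4.0-fold (0.60 log units) apart, beyond the scatter of two such steps. The morpholin-4-yl step fails to carry over in the same way, and since both comparisons read the same four compounds, they show a single departure from simple addition of the two changes, not two separate findings, and they do not show why it arises or whether it extends to other compounds: the same change on two cores in this assay, a 2.6-fold higher number (0.41 log units; beyond the scatter) from compound 1 to compound 3 and a 1.6-fold lower number (0.19 log units; within the scatter) from compound 2 to compound 4, 4.0-fold (0.60 log units) apart, beyond the scatter of two such steps.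

As far as these compounds go, it remains open whether a chlorine atom or a methoxy group in place of the methyl group would also depend on which group sits on the thiocarbonyl carbon. From the compounds shown here alone, it is equally open whether a piperidin-1-yl or diethylamino group on that carbon would pair with the methyl group as the morpholin-4-yl group does or as the pyrrolidin-1-yl group does.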